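The source may report more compounds than this note shows. Statements on the series, on what has been measured and on what is new or still open speak of the compounds shown alone.

Measured compounds:
- compound 1 `Cc1ncc(CO)c2c(Nc3cnccn3)c(NC(C)(C)C)oc12`: "not active" (no number reported)
- compound 2 `Cc1ncc(CO)c2c(Nc3ccccn3)c(NCc3ccccc3)oc12`: 4910 nM

Going by the values given here, in a functional assay on HEK293 cells for agonist activity at Toll-like receptor 8 (Homo sapiens), read by reporter gene assay (on this read-out higher numbers stand for an effect only at larger amounts of compound and lower numbers for an effect already at smaller amounts), compound 2 gives 4910 nM, the only number in the set. Among the compounds with values here, compound 1 gives "not active" (no number reported) in this assay, so no step between measured compounds can be stated. Compound 3 `Cc1ncc(CO)c2c(Nc3cnccn3)c(NCc3ccccc3)oc12` differs from compound 2 in one place: pyrazin-2-yl in place of pyridin-2-yl on a nitrogen on an aromatic ring. The pyrazin-2-yl group is shared with compound 1, which carries a different amine and shows no activity; that pairing is weak ground. A step from compound 2 to compound 3 of a 2.0-fold higher number from compound 2 to compound 3 (0.31 log units; beyond the scatter) toward weaker agonism is expected, beyond the scatter. Compound 3 is estimated at 10000 nM, range 3000 nM to 35000 nM.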

Compound 3, half-maximal effective concentration: 9790 nM
The estimate for compound 3 lay 1.0-fold (0.01 log units) above the measured number; low and high end bracket the measured number.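

In this assay, pyrazin-2-yl in place of pyridin-2-yl on a nitrogen on an aromatic ring gives a 2.0-fold higher number from compound 2 to compound 3 (0.30 log units; within the scatter), so this position accepts the change with a measurable response retained. Compound 3 gives 9790 nM and compound 1, with the same pyrazin-2-yl group but a different amine, gives "not active" (no number reported), so pyrazin-2-yl alone does not go with an absent response, and the step to compound 1 cannot be read. No measured evidence bears on this result.

Open, from the compounds shown here alone, is how a phenyl or pyrimidin-2-yl group would read at this nitrogen. Also open, going by these compounds, is how a cyclohexylamine would read with pyrazin-2-yl in place.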